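A few compounds are considered here, and "the series" means these few. Any claim that something is new, unique, unknown or untested is made for them only; others in the source may bear on it.

Compounds sharing one core differ here only in the group on a nitrogen on an aromatic ring. In a functional assay on DU-145 cells (Homo sapiens) for inhibition, read by trypan blue exclusion, with a stated time of 72 h (on this read-out higher numbers stand for weaker inhibition and lower numbers for stronger inhibition), compound 1 (`Cn1c(=O)c(S(=O)(=O)c2ccc(F)cc2F)cc2cnc(Nc3ccc4[nH]c(C(=O)O)cc4c3)nc21`) gives 10000 nM, compound 2 (`Cn1c(=O)c(S(=O)(=O)c2ccc(F)cc2F)cc2cnc(Nc3ccncn3)nc21`) gives 50000 nM, and compound 3 (`Cn1c(=O)c(S(=O)(=O)c2ccc(F)cc2F)cc2cnc(Nc3ccc4c(c3)CC(=O)N4)nc21`) gives 100000 nM. Compound 3 thus sits at the weak end of these numbers, which it shares with compound 2: the data show a 10-fold higher number from compound 1 to compound 3 (1.00 log units; beyond the scatter), and also a 2.0-fold higher number from compound 2 to compound 3 (0.30 log units; within the scatter). Compound 4 (`Cn1c(=O)c(S(=O)(=O)c2ccc(F)cc2F)cc2cnc(Nc3cnc4[nH]ccc4c3)nc21`) brings one more change at that place: a group of 9 heavy atoms (7 carbon, 2 nitrogen; one five-membered aromatic ring with 1 hetero atom, one six-membered aromatic ring with 1 hetero atom) in place of a group of 10 heavy atoms (8 carbon, 1 nitrogen, 1 oxygen; one five-membered non-aromatic ring with 1 hetero atom, one six-membered aromatic ring of carbon only), on a nitrogen on an aromatic ring. The other change measured there gave a 5.0-fold higher number from compound 1 to compound 2 (0.70 log units; beyond the scatter), so only a modest move towards a lower number is expected in this assay. The expected step is a 2.5-fold lower number from compound 3 to compound 4 (0.40 log units; beyond the scatter). The estimate for compound 4 is 40000 nM, with an expected range from 10000 nM to 100000 nM.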

Compound 4, half-maximal inhibitory concentration: 750 nM
Beside the measured number, compound 4's estimate is 53-fold (1.73 log units) above it; the measured number lies below the stated range.
By their numbers in this assay, from the lowest: compound 4; then compound 1; then compounds 2 and 3 (each within the scatter of the next).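

In this assay, among the compounds shown here, the group on this nitrogen turns out to matter far more than the earlier compounds showed, with a 130-fold lower number from compound 3 to compound 4 (2.12 log units; beyond the scatter), a 67-fold lower number from compound 2 to compound 4 (1.82 log units; beyond the scatter) and a 13-fold lower number from compound 1 to compound 4 (1.12 log units; beyond the scatter). Among these four compounds, the two lowest numbers belong to compound 4 and compound 1, the two that carry a five-membered aromatic ring, but this link rests on very few examples. Nothing measured here explains the large drop. As far as these compounds go, it remains open whether the lower number of compound 4 compared with compound 1 goes with the six-membered aromatic ring with 1 hetero atom or with the missing carboxylic acid. From the compounds shown here alone, it also remains open whether adding an amine or a methoxy group to the group in compound 4 would keep this strength.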